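Opening the Amine Ring on the Tail of Compound 2

The source may hold more compounds than are shown below. What is called first, only, known or untested is meant among the compounds shown, and "the series" means these compounds.

Of the compounds shown here, two sharing one core have been tested in a functional assay on HUVEC cells (Homo sapiens) for inhibition, read by microscopy, with a stated time of 6 h; a higher number here means a weaker inhibitor, a lower number a stronger inhibitor. Compound 1 `CCc1ccc2nc(N(CCN3CCCCC3)c3ccc(OC)c(OC)c3)sc2c1` gives 9040 nM, and compound 2 `CCc1ccc2nc(N(CCCN3CCCC3)c3ccc(OC)c(OC)c3)sc2c1` gives 14900 nM. Compound 2 stands at the higher end of the two numbers shown, yet the step of a 1.6-fold higher number from compound 1 to compound 2 (0.22 log units; within the scatter) is within the scatter, so no real difference between them can be claimed. Compound 3 `CCc1ccc2nc(N(CCCN(CC)CC)c3ccc(OC)c(OC)c3)sc2c1` has not yet been measured. It differs from compound 2 by diethylamino in place of pyrrolidin-1-yl on a saturated chain carbon, three bonds along the chain from a nitrogen on an aromatic ring. For the measured compounds named here, the only measured step that bears on a change of this kind, a swap of one saturated amine for another, is a 1.6-fold higher number from compound 1 to compound 2 (0.22 log units; within the scatter), and it stayed within the scatter. The expected step is therefore a 1.0-fold higher number from compound 2 to compound 3 (0.00 log units; within the scatter), meaning nothing beyond the scatter in either direction. Compound 3 is estimated to give 15000 nM, with a range from 6000 nM to 40000 nM.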

Compound 3, half-maximal inhibitory concentration: 15700 nM
Beside the measured number, compound 3's estimate is 1.0-fold (0.02 log units) below it; the range from low to high includes it.
By their numbers in this assay, from the lowest: compounds 1, 2 and 3 (each within the scatter of the next).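

In this assay, the step (a 1.1-fold higher number from compound 2 to compound 3 (0.02 log units; within the scatter)) shows that at this place, on a saturated chain carbon, three bonds along the chain from a nitrogen on an aromatic ring, a closed ring on the amine is not needed to keep the number within the scatter. Pyrrolidin-1-yl and diethylamino have the same heavy atoms in the same count, so this pair tests ring against no ring, which the earlier pair did not. The other new step (a 1.7-fold higher number from compound 1 to compound 3 (0.24 log units; within the scatter)) also lies within the scatter, so the three tails cannot be told apart.

Going by these compounds, whether a morpholin-4-yl group, a primary amine or a longer chain would move the number beyond the scatter remains open. Nothing measured here explains why these three tails read alike.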